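A few compounds are considered here, and "the series" means these few. Any claim that something is new, unique, unknown or untested is made for them only; others in the source may bear on it.

Compound 1 `N#Cc1c(-c2ccccc2)nc(SCC(=O)Nn2c(COc3ccc(Cl)cc3Cl)nc3ccccc3c2=O)[nH]c1=O` stands highest of the three numbers in a functional assay on the whole organism (strain albino) for inhibition, with Rattus norvegicus as the target, read by paw edema, with stated times of 1 h and 3 h, at a dose of 100 mg/kg by the oral route (a higher number here means a stronger effect of the compound at the dose given, a lower number a weaker effect), where compound 1 gives 86%. Compound 2 `N#Cc1c(-c2ccc(Cl)cc2)nc(SCC(=O)Nn2c(COc3ccc(Cl)cc3Cl)nc3ccccc3c2=O)[nH]c1=O` gives 64.9% and compound 3 `O=C(CSc1nc(-c2ccccc2)c(C(=O)O)c(=O)[nH]1)Nn1c(COc2ccc(Cl)cc2Cl)nc2ccccc2c1=O` gives 64.9%; the steps of a number 21.1 percentage points lower from compound 1 to compound 2 (beyond the scatter) and a number 21.1 percentage points lower from compound 1 to compound 3 (beyond the scatter) were both beyond the scatter. Compound 4 `Cn1c(SCC(=O)Nn2c(COc3ccc(Cl)cc3Cl)nc3ccccc3c2=O)nc(-c2ccccc2)c(C#N)c1=O` differs from compound 1 by methyl in place of hydrogen on an aromatic nitrogen. Going by the values given here, neither measured step bears directly on this change: one puts chloro in place of hydrogen on an aromatic carbon, the other carboxy in place of cyano, and no measured pair alters the aromatic nitrogen. Both changes from compound 1 lowered the read-out, so a modest drop is the more likely expectation. Compound 4 is therefore estimated at 70%, within 55% to 86%, a step of a number 16 percentage points lower from compound 1 to compound 4 (beyond the scatter) being expected.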

Compound 4, a percentage reported as inhibition, in the whole organism at one dose (the size of the read-out at that dose, not a potency): 59.7%
The estimate for compound 4 lay 10.3 percentage points above the measured number, within the range that was stated.
By their numbers in this assay, from the lowest: compounds 4, 2 and 3 (each within the scatter of the next); then compound 1.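

Going by these compounds alone, on the aromatic nitrogen, methyl in place of hydrogen lowers the read-out in this assay, giving a number 26.3 percentage points lower from compound 1 to compound 4 (beyond the scatter), so this position, untouched by the earlier steps, does respond to substitution. All three single changes shown from compound 1 now lower the number, and this one does so at a site away from the phenyl group and the nitrile. Nothing available explains the drop. Methyl is the only group shown on this nitrogen. As far as these compounds go, whether an ethyl group, a longer chain or a chain ending in an amine would give a similar number remains open.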